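Swapping the pyridine for a plain phenyl ring

The source may report more compounds than this note shows. Statements on the series, on what has been measured and on what is new or still open speak of the compounds shown alone.

Measured so far:
compound 1 `COc1ccc(S(=O)(=O)N2CCc3cccc(-c4ccc(C#N)cc4)c32)cc1` — 17.2 nM
compound 2 `COc1ccc(-c2cccc3c2N(S(=O)(=O)c2ccc(OC)cc2)CC3)cc1` — 211 nM
compound 3 `COc1ccc(S(=O)(=O)N2CCc3cccc(-c4ccncc4)c32)cc1` — 69.5 nM

Three compounds share a common core and differ only in the aromatic ring attached to it. In a functional assay on MKN-45 cells (Homo sapiens) for inhibition, with a stated time of 72 h (on this read-out higher numbers stand for weaker inhibition and lower numbers for stronger inhibition), compound 1 gives the lowest number, while compound 2 gives the highest. Compound 3 sits in between: the step of a 3.0-fold lower number from compound 2 to compound 3 (0.48 log units; beyond the scatter) and the step of a 4.0-fold higher number from compound 1 to compound 3 (0.61 log units; beyond the scatter) both lie beyond the scatter, so its place as the middle compound is secure.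

Compound 4 `COc1ccc(S(=O)(=O)N2CCc3cccc(-c4ccccc4)c32)cc1` has not yet been measured. It differs from compound 3 in one place: phenyl in place of pyridin-4-yl on an aromatic carbon.

Among the compounds with values here, two measured steps bear on this. The step of a 4.0-fold higher number from compound 1 to compound 3 (0.61 log units; beyond the scatter) shows that replacing the pyridin-4-yl with a phenyl ring carrying a nitrile improves the result, whereas the step of a 3.0-fold lower number from compound 2 to compound 3 (0.48 log units; beyond the scatter) shows that a phenyl carrying a methoxy does worse. A bare phenyl carries neither group, so the two steps point in opposite directions and no strong trend can be read from them. The expectation is therefore that compound 4 gives a number near compound 3, with the step of a 1.2-fold lower number from compound 3 to compound 4 (0.06 log units; within the scatter) expected to stay close to the scatter. The estimate for compound 4 in this assay is 60 nM, in a range from 20 nM to 200 nM.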

Compound 4, half-maximal inhibitory concentration: 117 nM
For compound 4 the middle estimate is 2.0-fold (0.29 log units) below the measured one; low and high end bracket the measured number.
By their numbers in this assay, from the lowest: compound 1; then compounds 3, 4 and 2 (each within the scatter of the next, the first and the last beyond it).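

Exchanging the ring carbon of the phenyl group for the nitrogen of pyridin-4-yl does not separate the two rings at this position in this assay, since the step is a 1.7-fold higher number from compound 3 to compound 4 (0.23 log units; within the scatter) and so gives no sign that the ring nitrogen matters here on its own. With the bare phenyl ring of compound 4 now available as a reference, the substituents on that ring can be judged directly: methoxy cannot be told apart from hydrogen, with a 1.8-fold lower number from compound 2 to compound 4 (0.26 log units; within the scatter), whereas nitrile stands clearly apart, with a 6.8-fold higher number from compound 1 to compound 4 (0.83 log units; beyond the scatter), so among the groups shown only the nitrile on the phenyl ring has a measurable effect. Nothing measured here accounts for why the nitrile stands apart from hydrogen and methoxy.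

On these data alone, whether this effect belongs to the nitrile alone stays open, and a phenyl ring carrying a carboxylic acid, a primary amide or a trifluoromethyl group in its place would test that. Also open, as far as these compounds go, is whether a pyridine ring that itself carries a nitrile would behave like compound 1.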